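The source may hold more compounds than are shown below. What is called first, only, known or untested is meant among the compounds shown, and "the series" means these compounds.

Compound 1 `CCCCO/N=C/c1c(N)ncnc1Oc1ccc2[nH]c(C)cc2c1F` gives the lowest number of the three compounds measured in a functional assay on HCT-116 cells (Homo sapiens) for antiproliferative activity (a higher number here means a weaker inhibitor, a lower number a stronger inhibitor), at 1000 nM. Compound 3 `Cc1cc2c(F)c(Oc3ncnc(N)c3/C=N/O)ccc2[nH]1` shows 1140 nM in this assay, and compound 2 `Cc1cc2c(F)c(Oc3ncnc(N)c3/C=N/OCC3CCCCC3)ccc2[nH]1` shows 16100 nM. Compound 4 `CCCO/N=C/c1c(N)ncnc1Oc1ccc2[nH]c(C)cc2c1F` differs from compound 1 in one place: hydrogen in place of methyl on a saturated chain carbon, three bonds along the chain from an oxygen on an unsaturated carbon. For the measured compounds named here, the step that bears most directly on this shortening is the one from compound 1 to compound 3, a 1.1-fold higher number from compound 1 to compound 3 (0.06 log units; within the scatter), where the whole butyl was removed without effect. The larger group in compound 2 went the other way, a 16-fold higher number from compound 1 to compound 2 (1.21 log units; beyond the scatter), so growth rather than loss of chain is what matters here. Removing a single methyl is therefore expected to give no step beyond the scatter, no change at the digits printed from compound 1 to compound 4 (within the scatter). Compound 4 is estimated at 1000 nM, within 500 nM to 2000 nM.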

Compound 4, half-maximal inhibitory concentration: 30 nM
Compound 4: the middle estimate sits 33-fold (1.52 log units) above what was measured; the whole stated range lies above it.
By their numbers in this assay, from the lowest: compound 4; then compounds 1 and 3 (each within the scatter of the next); then compound 2.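

In this assay this position proves sharply sensitive to chain length: a 33-fold lower number from compound 1 to compound 4 (1.52 log units; beyond the scatter) follows removal of the end methyl, although hydrogen on the oxygen in compound 3 had matched butyl in compound 1. Propyl also stands clear of hydrogen with a 38-fold lower number from compound 3 to compound 4 (1.58 log units; beyond the scatter) and of cyclohexylmethyl with a 540-fold lower number from compound 2 to compound 4 (2.73 log units; beyond the scatter) so across these compounds the numbers do not move in one direction with chain size. As far as these compounds go, whether an ethyl on the oxygen, or a propyl chain ending in an amine, would hold this level remains open. No measurement offered here explains the sharp change at propyl.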